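A few compounds are considered here, and "the series" means these few. Any claim that something is new, unique, unknown or untested is made for them only; others in the source may bear on it.

Measured compounds: compound 1 `Cc1cccc(NC(=O)CSC(=S)N[C@H]2CCOC2=O)c1`; compound 2 `CCCCCCCCCCCCSC(=S)N[C@H]1CCOC1=O`; compound 3 `O=C(CCl)Nc1ccc(C(=O)/C=C/c2ccc(Cl)cc2)cc1`.

In a functional assay on EC9706 cells (Homo sapiens) for cytotoxicity, read by MTT assay, with a stated time of 72 h (a lower number here means a stronger inhibitor, a higher number a weaker inhibitor), compound 3 gives 8340 nM, the lowest of the two numbers shown. Compound 2 gives 58300 nM, a higher number than compound 3 by a gap beyond the usual scatter. Compound 1 reaches only a limit of the assay, > 128000 nM. Compound 4 `O=C(CCl)Nc1ccc(C(=O)/C=C/c2ccc([N+](=O)[O-])cc2)cc1` differs from compound 3 in one place: nitro in place of chloro on an aromatic carbon. No measured pair shows this change, so no size for such a step in this assay can be drawn from the compounds shown. Compound 4 is expected to stay close to compound 3, with the step from compound 3 to compound 4 estimated as a 1.3-fold lower number from compound 3 to compound 4 (0.11 log units; within the scatter), within the scatter. Compound 4 is therefore estimated at 6500 nM, between 2000 nM and 22000 nM.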

Compound 4, half-maximal inhibitory concentration: 3670 nM
The estimate for compound 4 lay 1.8-fold (0.25 log units) above the measured number; measured number inside the range.
By their numbers in this assay, from the lowest: compound 4; then compound 3; then compound 2. At a limit, above all of these: compound 1.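

Nitro in place of chloro on an aromatic carbon, para to a large group, gives a 2.3-fold lower number from compound 3 to compound 4 (0.36 log units; beyond the scatter) in this assay. This modest step is the first direct reading of a single change among these compounds, and it shows that the number responds to the group at this position. No measurement shown here accounts for the step. From the compounds shown here alone, whether an amine, a methoxy group or a carboxylic acid at this position would lower the number further remains open. So does whether moving the nitro elsewhere on the ring would keep the step.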